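The compounds below may be only part of what the source reports. "The series", "measured", "known", "first", "only" and "open" are said of these compounds alone.

Measured so far:

Compound 1, `COc1cc(-c2cc(/C=C/C(=O)c3ccc(N)cc3)[nH]n2)cc(OC)c1OC`: 3930 nM
Compound 2, `COc1ccc(-c2cc(/C=C/C(=O)c3ccc(N)cc3)[nH]n2)cc1OC`: 4400 nM
Compound 3, `COc1cc(C(=O)/C=C/c2cc(-c3cc(OC)c(OC)c(OC)c3)n[nH]2)cc(OC)c1OC`: 4580 nM

All three were tested in a functional assay on SF-268 cells (Homo sapiens) for inhibition, read by sulforhodamine B assay, with a stated time of 48 h; a lower number here means a stronger inhibitor of growth, a higher number a weaker inhibitor of growth. Compound 1 gives 3930 nM, compound 2 gives 4400 nM and compound 3 gives 4580 nM. The three numbers lie close together, and none of the gaps between them goes beyond the usual scatter, so no one of them can be called stronger or weaker than the others.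

Compound 1 and compound 2 share a core and differ in one place, (hydrogen in place of methoxy on an aromatic carbon). The step this made in this assay is a 1.1-fold higher number from compound 1 to compound 2 (0.05 log units; within the scatter), a step too small to count as a real change.

Compound 3 carries a different core, and the difference between the two cores is not broken down here. From compound 3 the unmeasured compound 4, `COc1ccc(-c2cc(/C=C/C(=O)c3cc(OC)c(OC)c(OC)c3)[nH]n2)cc1OC`, is reached by hydrogen in place of methoxy on an aromatic carbon. The surroundings of the place are the same as in the step from compound 1 to compound 2, so this is the same change made on the other core.

Since that earlier step stayed within the scatter, the expected step here is likewise small: a 1.1-fold higher number from compound 3 to compound 4 (0.04 log units; within the scatter), an expectation that rests on a 1.1-fold higher number from compound 1 to compound 2 (0.05 log units; within the scatter), read together with compound 3 at 4580 nM. Compound 4 is therefore expected to give about 5000 nM in this assay, with a likely range from 2500 nM to 10000 nM.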

Compound 4, concentration for total growth inhibition: 3900 nM
For compound 4 the middle estimate is 1.3-fold (0.11 log units) above the measured one, and the stated range covers the measured number.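

Replacing one methoxy group with hydrogen on the aromatic ring gives, in this assay, a 1.2-fold lower number from compound 3 to compound 4 (0.07 log units; within the scatter). Set beside the same change on the other core, this step does not differ from the earlier one: the same change on two cores in this assay, a 1.1-fold higher number (0.05 log units; within the scatter) from compound 1 to compound 2 and a 1.2-fold lower number (0.07 log units; within the scatter) from compound 3 to compound 4, 1.3-fold (0.12 log units) apart, within the scatter of two such steps. So, on the two cores shown, this swap behaves alike in that neither step can be told apart from the noise of repeated measurements, and the opposite directions of the two steps carry no meaning; but a change that does almost nothing on both cores is a weak test of transfer, and it does not show that a larger effect would carry over in the same way, nor that a third core would behave like these two.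

The compounds shown offer only hydrogen as the replacement for methoxy, so it remains open whether a hydroxyl group, a carboxylic acid or a longer alkoxy chain at the same place would move the number beyond the scatter. On these data alone, it also remains open whether taking away further methoxy groups from the same ring would still leave growth inhibition unchanged.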